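Compound 3 Loses One Methoxy Group

A few compounds are considered here, and "the series" means these few. Any claim that something is new, unique, unknown or untested is made for them only; others in the source may bear on it.

In a functional assay on A549 cells (Homo sapiens) for inhibition, read by sulforhodamine B assay, with a stated time of 48 h (on this read-out lower numbers stand for stronger inhibition of growth and higher numbers for weaker inhibition of growth), compound 1 (`COc1cc(/C=C/C(=O)/C=C/c2sccc2C)cc(OC)c1OC`) gives 9310 nM and compound 2 (`COc1ccc(C=C(C(=O)/C=C/c2cc(OC)c(OC)c(OC)c2)C(=O)/C=C/c2cc(OC)c(OC)c(OC)c2)cc1OC`) gives 370 nM. Compound 3 (`COc1cc(/C=C/C(=O)C(=Cc2ccc(OC)c(OC)c2)C(=O)/C=C/c2ccc(O)c(OC)c2)ccc1O`) gives 430 nM, which lies within the scatter of compound 2 and far from compound 1. Compound 4 (`COc1cccc(C=C(C(=O)/C=C/c2ccc(O)c(OC)c2)C(=O)/C=C/c2ccc(O)c(OC)c2)c1`) has hydrogen in place of methoxy on an aromatic carbon, turning 3,4-dimethoxyphenyl into 3-methoxyphenyl: hydrogen in place of methoxy on an aromatic carbon. Going by the values given here, no measured pair isolates this change. Compound 2 at 370 nM differs from compound 3 in more than one place, yet the two stay within the scatter, so no large shift is expected. The expected change is a 1.2-fold higher number from compound 3 to compound 4 (0.07 log units; within the scatter), a small weakening that stays within the scatter. The estimate for compound 4 is 500 nM, with a range of 200 nM to 1300 nM.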

Compound 4, concentration for 50% growth inhibition: 640 nM
Estimate against measurement, compound 4: 1.3-fold (0.11 log units) below; measured number inside the range.
By their numbers in this assay, from the lowest: compounds 2, 3 and 4 (each within the scatter of the next); then compound 1.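

In this assay, going by these compounds alone, the step of a 1.5-fold higher number from compound 3 to compound 4 (0.17 log units; within the scatter) is the first to isolate a single change, and it lies within the scatter, so compound 3 and compound 4 cannot be told apart. At this carbon, ortho to a methoxy group and para to a large group, 3-methoxyphenyl therefore reads the same as 3,4-dimethoxyphenyl in this one pair. No evidence on why this is so is available. The compounds shown leave open whether an amine or a fluorine at this carbon would read differently, and whether the remaining methoxy group can also be replaced by hydrogen.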